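Lengthening the Pentyl Chain of Compound 2

The source may report more compounds than this note shows. Statements on the series, on what has been measured and on what is new or still open speak of the compounds shown alone.

Compound 1 `CCCCCc1cn(CC=C(C)C)nn1`: 3.46
Compound 2 `CCCCCc1cn(C/C=C(\C)CCC=C(C)C)nn1`: 5.45
Compound 3 `COC(=O)c1cn(C/C=C(\C)CCC=C(C)C)nn1`: 3.2

In a physicochemical assay for lipophilicity, measured as octanol-water partition (on this read-out higher numbers stand for higher lipophilicity and lower numbers for lower lipophilicity), compound 2 gives 5.45, the highest of the three measured values. Compound 1 gives 3.46 and compound 3 gives 3.2, both clearly lower. Two single-point steps connect these compounds. The first, a number 1.99 log units higher from compound 1 to compound 2 (beyond the scatter), comes from attaching 3-methylbut-2-en-1-yl to the side chain on the ring nitrogen. The second, a number 2.25 log units lower from compound 2 to compound 3 (beyond the scatter), comes from replacing the pentyl group on the ring carbon with methoxycarbonyl.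

Compound 4 `CCCCCCCCc1cn(C/C=C(\C)CCC=C(C)C)nn1` is not yet measured. It differs from compound 2 in one place: propyl in place of hydrogen on a saturated chain carbon, five bonds along the chain from an aromatic carbon. This is a pure extension of the pentyl chain by a propyl fragment, with no new ring, donor, acceptor or charge.

Both measured steps bear on it, since each involves adding or removing carbon chain on the shared core, and both were large. The step of a number 1.99 log units higher from compound 1 to compound 2 (beyond the scatter) shows that adding chain raised the value markedly, and the step of a number 2.25 log units lower from compound 2 to compound 3 (beyond the scatter) shows that removing the pentyl chain lowered it markedly. A rise beyond the scatter is therefore expected for compound 4: a number 1.45 log units higher from compound 2 to compound 4 (beyond the scatter). This expected rise is kept smaller than the step of a number 1.99 log units higher from compound 1 to compound 2 (beyond the scatter); propyl is the shorter of the two added fragments. Compound 4 is estimated to give about 6.9, most likely between 6.3 and 7.6.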

Compound 4, partition coefficient: 6.92
Compound 4: the middle estimate sits 0.02 log units below what was measured, and the stated range covers the measured number.
By their numbers in this assay, from the lowest: compounds 3 and 1 (each within the scatter of the next); then compound 2; then compound 4.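

Adding propyl on a saturated chain carbon, five bonds along the chain from an aromatic carbon, gives a number 1.47 log units higher from compound 2 to compound 4 (beyond the scatter) in this assay. Going by these compounds alone, the earlier steps changed the side chain on the ring nitrogen or swapped the whole pentyl group for methoxycarbonyl, so this is the first step here that changes only the length of the pentyl chain. It shows that this far stretch of the chain still counts and that the value of compound 2 was no ceiling for this series. No measurement shown here explains the size of this step.

From the compounds shown here alone, whether a longer chain at this place would raise the number further remains open. So does what a hydroxyl group or an amine would do at the same place.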